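The source may hold more compounds than are shown below. What is called first, only, known or untested is meant among the compounds shown, and "the series" means these compounds.

Measured compounds in a functional assay on A549 cells (Homo sapiens), read by MTT assay, with a stated time of 72 h; on this read-out lower numbers stand for stronger inhibition and higher numbers for weaker inhibition:

- Compound 1 `C#Cc1cn([C@@H]2O[C@H](CO)[C@@H](O)[C@H]2O)c2ncnc(NC)c12`: in this assay compound 1 reaches only the limit > 20000 nM, which is a limit and not a number.
- Compound 2 `CNc1ncnc2c1c(I)cn2[C@@H]1O[C@H](CO)[C@@H](O)[C@H]1O`: in this assay compound 2 reaches only the limit > 100000 nM, again a limit and not a number.
- Compound 3 `C#Cc1cn([C@@H]2O[C@H](CO)[C@@H](O)[C@H]2O)c2ncnc(OC)c12`: in this assay compound 3 gives 8160 nM, the only number among the three.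

Two single changes connect the measured compounds. From compound 1 to compound 3 the core changes by methoxy in place of methylamino on an aromatic carbon, and the step in this assay is an at least 2.4-fold lower number from compound 1 to compound 3 (0.38 log units; beyond the scatter). From compound 1 to compound 2 the change is iodo in place of ethynyl on an aromatic carbon, and here the step is a step that the two limits leave unreadable from compound 1 to compound 2: both ends sit at limits, the limit of > 20000 nM in this assay, at which 1 of the 3 values shown sits, for compound 1 and the limit of > 100000 nM in this assay, at which 1 of the 3 values shown sits, for compound 2, so its size cannot be read.

Compound 4 `COc1ncnc2c1c(I)cn2[C@@H]1O[C@H](CO)[C@@H](O)[C@H]1O` has not yet been measured in this assay. Among the compounds with values here, it differs from compound 3 by iodo in place of ethynyl on an aromatic carbon, which is the same change as the one from compound 1 to compound 2, at the same place in the same words. Since that earlier step is unreadable, compound 4 rests only on compound 3 at 8160 nM as its starting point. Beyond that, the only further hint is that compound 2, which carries the same change, stays at a limit in the same assay.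

On that basis, compound 4 is expected to give about 30000 nM in this assay, with a range from 8000 nM to 150000 nM. The step from compound 3 to compound 4 that this estimate means is a 3.7-fold higher number from compound 3 to compound 4 (0.57 log units; beyond the scatter), an expectation and not a measurement, and a limit rather than a number is a real possibility.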

Compound 4, half-maximal inhibitory concentration: > 20000 nM
Compound 4 was reported as a limit (the forecaster's own chance of this, stated with the estimate: 50%); the middle value is on the limit's open side.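

In this assay, iodo in place of ethynyl on the core of compound 3 gives an at least 2.4-fold higher number from compound 3 to compound 4 (0.38 log units; beyond the scatter), so on this core the change weakens inhibition beyond the scatter, and the printed size is only a lower bound on the true step. Compound 4 gives a limit and not a number: the limit of > 20000 nM in this assay, at which 2 of the 4 values shown sit. The same change on the core of compound 1 runs between two limits, as does the methoxy for methylamino step between compound 2 and compound 4, so neither step can be read; the series shows the direction of the iodo change on one core only and does not show that it carries over to the other core, in direction or in size.

Within the data shown here, still open is how a nitrile or a longer chain such as propynyl on that aromatic carbon would read in this assay, with compound 3 at 8160 nM as the only number to compare against. Also open, from the compounds shown here alone, is how a free amino group or an ethoxy group in place of methoxy would read with ethynyl kept, and whether any iodo compound gives a number rather than a limit.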